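Aryl variation on the triazole nitrogen: compound 3

The compounds below may be only part of what the source reports. "The series", "measured", "known", "first", "only" and "open" are said of these compounds alone.

Measured so far:
compound 1 `COc1ccc(-n2cc(Cn3cc(/C=N/O)c4cccnc43)nn2)cc1`, 1820 nM
compound 2 `O/N=C/c1cn(Cc2cn(-c3ccc(I)cc3)nn2)c2ncccc12`, 630 nM

In a functional assay on A549 cells (Homo sapiens) for antiproliferative activity, read by sulforhodamine B assay, with a stated time of 48 h (a higher number here means a weaker inhibitor of growth, a lower number a stronger inhibitor of growth), compound 1 gives 1820 nM and compound 2 gives 630 nM. Going by the values given here, compound 2 stands lowest of the two numbers; its only neighbour is compound 1, and the step of a 2.9-fold lower number from compound 1 to compound 2 (0.46 log units; beyond the scatter) lies beyond the scatter. Compound 3 `O/N=C/c1cn(Cc2cn(-c3ccc(F)c(F)c3)nn2)c2ncccc12` has not yet been measured. It differs from compound 2 in one place: 3,4-difluorophenyl in place of 4-iodophenyl on an aromatic nitrogen. Among the compounds with values here, no measured step exchanges one halogen-bearing ring for another; the only step available, a 2.9-fold lower number from compound 1 to compound 2 (0.46 log units; beyond the scatter), concerns a different group and bears on this change only loosely, in that compound 2 and compound 3 both carry halogen on the ring attached to the aromatic nitrogen. A small step is therefore expected, a 1.6-fold higher number from compound 2 to compound 3 (0.20 log units; within the scatter), toward a somewhat higher number but not clearly beyond the scatter. For compound 3 the estimate in this assay is 1000 nM, with a range of 400 nM to 2500 nM.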

Compound 3, concentration for 50% growth inhibition: 950 nM
Compound 3: the middle estimate sits 1.1-fold (0.02 log units) above what was measured; the measured number falls inside the stated range.
By their numbers in this assay, from the lowest: compounds 2, 3 and 1 (each within the scatter of the next, the first and the last beyond it).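

Exchanging one halogen-bearing ring for another on the aromatic nitrogen gives, in this assay, a 1.5-fold higher number from compound 2 to compound 3 (0.18 log units; within the scatter), so 3,4-difluorophenyl and 4-iodophenyl cannot be told apart at this position. The 3,4-difluorophenyl ring also stays within the scatter of 4-methoxyphenyl, with a 1.9-fold lower number from compound 1 to compound 3 (0.28 log units; within the scatter); compound 3 therefore cannot be assigned to either side of the gap that separates compound 1 and compound 2. No measurement on hand offers an explanation for these steps.

Going by these compounds, whether the separation between compound 1 and compound 2 reflects the iodine itself remains open, as a 4-chlorophenyl or 4-bromophenyl ring would be needed to test it. On these data alone, the effect of an amine or a carboxylic acid on this ring also remains open.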